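The source may report more compounds than this note shows. Statements on the series, on what has been measured and on what is new or still open speak of the compounds shown alone.

Compound 1 `COc1ccc2nc(-c3ccc(N/C=C\C(=O)c4ccc(OC)c(O)c4)c(C)c3)sc2c1` gives 18000 nM in a functional assay on A549 cells (Homo sapiens) for antiproliferative activity, read by sulforhodamine B assay, with a stated time of 48 h; on this read-out lower numbers stand for stronger inhibition and higher numbers for weaker inhibition; compound 2 `COc1ccc2nc(-c3ccc(N/C=C\C(=O)c4ccc(OC)c([N+](=O)[O-])c4)c(C)c3)sc2c1` gives 13600 nM.

Compound 2 and compound 1 lie within the scatter of each other, as a 1.3-fold lower number from compound 1 to compound 2 (0.12 log units; within the scatter) shows. Compound 3 `COc1ccc2nc(-c3ccc(N/C=C\C(=O)c4cc(OC)c(OC)c([N+](=O)[O-])c4)c(C)c3)sc2c1` differs from compound 2 by methoxy in place of hydrogen on an aromatic carbon. Within the data shown here, the only step measured so far exchanges nitro for hydroxy and therefore bears little on adding a methoxy; no step in this assay tests that change. Compound 3 is thus expected to stay close to compound 2, with a step of a 1.0-fold lower number from compound 2 to compound 3 (0.02 log units; within the scatter) not expected to exceed the scatter. The estimate for compound 3 is 13000 nM, within 4500 nM to 38000 nM.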

Compound 3, half-maximal inhibitory concentration: 22100 nM
Estimate against measurement, compound 3: 1.7-fold (0.23 log units) below; the measured number falls inside the stated range.
By their numbers in this assay, from the lowest: compounds 2, 1 and 3 (each within the scatter of the next).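

In this assay, the step of a 1.6-fold higher number from compound 2 to compound 3 (0.21 log units; within the scatter) gives the first direct test of methoxy in place of hydrogen on this aromatic carbon, ortho to a methoxy group and meta to a nitro group. At this position, the added methoxy leaves compound 3 within the scatter of compound 2. No measurement available here accounts for this result.

Going by these compounds, it remains open whether an amine, a carboxylic acid or a longer chain on this carbon would move the number beyond the scatter. On these data alone, it is also open whether the added methoxy would behave the same way with hydroxy in place of the nitro group.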